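Swapping a Sulfo Group for an Imidazole Ring

The source may report more compounds than this note shows. Statements on the series, on what has been measured and on what is new or still open speak of the compounds shown alone.

Compound 1, `CCCCCCCCCCCC(=O)OC[C@H](CSC[C@@H](N)C(=O)NCCCS(=O)(=O)O)OC(=O)CCCCCCCCCCC`, gives 5560 nM in an assay on HEK293 cells for agonist activity at Toll-like receptor 2 (Homo sapiens); on this read-out higher numbers stand for an effect only at larger amounts of compound and lower numbers for an effect already at smaller amounts.
Compound 2, `CCCCCCCCCCCC(=O)OC[C@H](CSC[C@@H](N)C(=O)N[C@@H](CO)C(=O)NCCOCCOCCOCCC(=O)O)OC(=O)CCCCCCCCCCC`, gives 4940 nM in this assay.
Compound 3, `CCCCCCCCCCCC(=O)OC[C@H](CSC[C@@H](N)C(=O)NCCCOCCOCCOCCCNC(=O)C(N)CS)OC(=O)CCCCCCCCCCC`, gives 247 nM in this assay.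

Compound 1 sits at the upper end of these three numbers. Its value and that of compound 2 lie within the usual scatter of each other, so nothing separates them, while compound 3 lies well below both, beyond the scatter. Compound 4, `CCCCCCCCCCCC(=O)OC[C@H](CSC[C@@H](N)C(=O)NCCCn1ccnc1)OC(=O)CCCCCCCCCCC`, differs from compound 1 in a single place: 1H-imidazol-1-yl in place of sulfo on a saturated chain carbon, three bonds along the chain from an amide-type nitrogen. Going by the values given here, no measured pair shows this kind of change, so its effect cannot be read from the data. Compound 4 is expected to give 2500 nM, within a range from 500 nM to 12000 nM. This amounts to an expected step of a 2.2-fold lower number from compound 1 to compound 4 (0.35 log units; beyond the scatter), a modest move downward that may not exceed the scatter.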

Compound 4, half-maximal effective concentration: 410 nM
Compound 4: middle estimate off by 6.1-fold (0.79 log units), on the high side, and the stated range ends above it.
By their numbers in this assay, from the lowest: compounds 3 and 4 (each within the scatter of the next); then compounds 2 and 1 (each within the scatter of the next).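

Going by these compounds alone, this position is sensitive to what it carries: in this assay, 1H-imidazol-1-yl in place of sulfo gives a 14-fold lower number from compound 1 to compound 4 (1.13 log units; beyond the scatter) and is the only single-place change so far. Replacing sulfo here therefore yields an effect at much smaller amounts of compound, a shift far larger than the usual scatter. Nothing available explains why this change has so large an effect.

On these data alone, it remains open whether a phenyl ring in this place would give a similar step. Also open, as far as these compounds go, is whether a butyl chain carrying 1H-imidazol-1-yl would keep it.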